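The compounds below may be only part of what the source reports. "The series", "measured", "known", "first", "only" and "open" are said of these compounds alone.

Working notes on the series.

Compound 1 `COc1ccc2c(c1)C(=O)CCN2c1nc(Cl)nc2ccccc12` and compound 2 `COc1ccc2c(c1)C(=O)CCN2c1nc(C)nc2ccccc12` share one core and differ at a single aromatic carbon. In a functional assay on KBVIN cells (Homo sapiens) for cytotoxicity, read by sulforhodamine B assay (a lower number here means a stronger inhibitor of growth, a higher number a weaker inhibitor of growth), compound 1 gives 33 nM, and compound 2 gives 21 nM. The change between them is methyl in place of chloro on an aromatic carbon; the step it made is a 1.6-fold lower number from compound 1 to compound 2 (0.20 log units; within the scatter), so the two values stand together.

Compound 3 `COc1ccc2c(c1)CCCN(c1nc(Cl)nc3ccccc13)C2` carries the chloro group of compound 1 on a different core; the difference between the two cores is not broken down here. In this assay compound 3 gives 5450 nM, the highest of the three measured values and well separated from compound 1 and compound 2.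

Compound 4 `COc1ccc2c(c1)CCCN(c1nc(C)nc3ccccc13)C2` has not yet been measured. It differs from compound 3 by methyl in place of chloro on an aromatic carbon. The place description is identical, word for word, to that for the change from compound 1 to compound 2, so this is the same change made on the second core, occurring twice among the compounds shown.

On that basis compound 4 is expected to repeat the small step seen between compound 1 and compound 2: the expected step is a 1.6-fold lower number from compound 3 to compound 4 (0.20 log units; within the scatter), set beside the measured 1.6-fold lower number from compound 1 to compound 2 (0.20 log units; within the scatter), and resting on compound 3 giving 5450 nM as the starting point. For the measured compounds named here, since the only precedent lies within the scatter, the estimate for compound 4 stays close to compound 3, with a wide interval because only one precedent exists and the core differs. Compound 4 is estimated at 3400 nM, between 1400 nM and 9000 nM.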

Compound 4, concentration for 50% growth inhibition: 14800 nM
Compound 4: the middle estimate sits 4.4-fold (0.64 log units) below what was measured; measured number above the stated range.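

In this assay, methyl in place of chloro on an aromatic carbon does not carry over unchanged from the core of compound 1 to the second core, and the two steps differ by more than the scatter of two such steps: the same change on two cores in this assay, a 1.6-fold lower number (0.20 log units; within the scatter) from compound 1 to compound 2 and a 2.7-fold higher number (0.43 log units; beyond the scatter) from compound 3 to compound 4, 4.3-fold (0.63 log units) apart, beyond the scatter of two such steps. On the second core the change now gives a 2.7-fold higher number from compound 3 to compound 4 (0.43 log units; beyond the scatter) as a modest step, whereas on the core of compound 1 the two values stand together, so the earlier step is not a reliable guide to the step on the second core. This shows only that the outcome of this one change differs between these two cores; it does not show which structural difference between the cores is responsible, and two steps give no rule for any further core.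

The compounds shown leave open how an amine, a methoxy group or a longer chain would behave in place of chloro on this aromatic carbon, on either core. They also leave open whether the different outcome belongs to the carbonyl of the core of compound 1 or to some other feature that separates the two cores.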